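A few compounds are considered here, and "the series" means these few. Any claim that something is new, unique, unknown or untested is made for them only; others in the source may bear on it.

Compound 2 `COc1cc2c(Oc3ccc(NC(=O)N/N=C/c4ccncc4)cc3F)ccnc2cc1OCCCN1CCCCC1` is measured in a functional assay on A549 cells (Homo sapiens) for cytotoxicity, read by MTT assay, with a stated time of 72 h (a lower number here means a stronger inhibitor, a higher number a weaker inhibitor), at 840 nM. Among the two measured compounds it holds the highest number, but the other one sits within the scatter of it: compound 1 `COc1cc2c(Oc3ccc(NC(=O)N/N=C/c4ccc(OC(F)(F)F)cc4)cc3F)ccnc2cc1OCCCN1CCCCC1` gives 590 nM in this assay, and a 1.4-fold higher number from compound 1 to compound 2 (0.15 log units; within the scatter). Compound 3 `COc1cc2c(Oc3ccc(/C=N/NC(=O)Nc4ccccc4)cc3F)ccnc2cc1OCCCN1CCCCC1` is not yet measured. Its change from compound 2 is a group of 12 heavy atoms (8 carbon, 3 nitrogen, 1 oxygen; one six-membered aromatic ring of carbon only) in place of a group of 12 heavy atoms (7 carbon, 4 nitrogen, 1 oxygen; one six-membered aromatic ring with 1 hetero atom), on an aromatic carbon. Within the data shown here, only one measured step bears on it, a 1.4-fold higher number from compound 1 to compound 2 (0.15 log units; within the scatter), which also exchanged one aromatic ring for another and stayed within the scatter. No measured pair shows a change of this kind in the linking group itself, so that part of the change carries no evidence either way. On this basis a step of no more than the scatter is expected, without a clear direction. The step expected is a 1.1-fold lower number from compound 2 to compound 3 (0.02 log units; within the scatter). Compound 3 is estimated at 800 nM in this assay, within a range from 250 nM to 2500 nM.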

Compound 3, half-maximal inhibitory concentration: 280 nM
For compound 3 the middle estimate is 2.9-fold (0.46 log units) above the measured one; the range from low to high includes it.
By their numbers in this assay, from the lowest: compound 3; then compounds 1 and 2 (each within the scatter of the next).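

At this aromatic carbon, para to a large group, the exchange gives a 3.0-fold lower number from compound 2 to compound 3 (0.48 log units; beyond the scatter) in this assay, the first step among these compounds to lie beyond the scatter. The earlier exchange of one aromatic ring for another, a 1.4-fold higher number from compound 1 to compound 2 (0.15 log units; within the scatter), stayed within the scatter, so only the new step shows that a change at this place can move the number; yet it alters both the terminal ring and the way the linking group is attached, and this single step cannot divide its size between the two. Nothing available accounts for the lower number.

Going by these compounds, it remains open whether the linking group of compound 3 would keep that number with pyridin-4-yl as its terminal ring. Also open, on these data alone, is how that linking group would respond to a carboxylic acid or a dimethylamino group on its terminal ring.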